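The compounds below may be only part of what the source reports. "The series", "measured", "known", "first", "only" and "open" are said of these compounds alone.

Measured so far in an ADME assay on Vero cells (Chlorocebus sabaeus) for cytotoxicity, read by MTT assay, with a stated time of 72 h; on this read-out higher numbers stand for an effect only at larger amounts of compound and lower numbers for an effect already at smaller amounts:
Compound 1 `O=C(Nc1nc(-c2ccccn2)cs1)c1cccc([N+](=O)[O-])c1`: "not determined" (no result reported)
Compound 2 `O=C(Nc1nc(-c2ccccn2)cs1)c1ccccc1Br`: 3500 nM

Among the measured compounds shown here, compound 2, at 3500 nM, carries the only number available, so it cannot yet be ranked, as compound 1 has no result to compare with it. Compound 3 `O=C(Nc1nc(-c2ccccn2)cs1)c1cccc(Cl)c1` has not been measured. It shares the core of compound 2 and differs in one place: 3-chlorophenyl in place of 2-bromophenyl on a carbonyl carbon. For the measured compounds named here, no pair of measured compounds shows how large a step such a swap gives in this assay, so there is no direct precedent. Going by the values given here, the one anchor is compound 2 at 3500 nM, and the expectation is that compound 3 stays close to it, with no change beyond the usual scatter and no firm direction. The estimated step is a 1.1-fold higher number from compound 2 to compound 3 (0.06 log units; within the scatter). For compound 3 the expected value is 4000 nM. The estimated range for compound 3 runs from 1500 nM to 11000 nM, and it is kept wide, as a single measured number is a thin base.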

Compound 3, half-maximal effective concentration: 7000 nM
Compound 3: middle estimate off by 1.8-fold (0.24 log units), on the low side; measured number inside the range.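

In this assay, putting 3-chlorophenyl in place of 2-bromophenyl on a carbonyl carbon gives a 2.0-fold higher number from compound 2 to compound 3 (0.30 log units; within the scatter), so this swap does not clearly separate the two compounds. Among the compounds shown here, this is the first step at this place with a number at both ends, and it offers no sign that the swap matters in this cell test. The swap alters both the halogen and the number in the group's name at once, and this single step cannot divide its size between those two differences; nothing available here offers an explanation for the result.

Still open, as far as these compounds go, is whether a different kind of group at this place, such as a carboxylic acid, an amine or a longer chain in place of the halogen-bearing phenyl ring, would shift the number beyond the usual scatter. Also open, from the compounds shown here alone, is what bromine and chlorine do when compared with the same number in the group's name, which would show whether either difference matters on its own.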